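Methyl in place of iodo: notes toward compound 3

This account rests on a few compounds, and the source may have more. Where it says the series, first, only, none or still open, it means among the compounds named here.

Compound 1 `Nc1ccc(-c2nc3ccccc3s2)cc1I` sets the upper reference in a functional assay on MCF7 cells (Homo sapiens) for cytotoxicity (a higher number here means a weaker inhibitor, a lower number a stronger inhibitor), where compound 1 gives < 1 nM. Going by these compounds, that reading is a limit of the assay and not a number, so the true value of compound 1 stays open. Among the measured compounds shown here, compound 2 `CC(=O)Nc1ccc(-c2nc3cc(O)ccc3s2)cc1C` reads 72500 nM, far weaker on the values shown, but no single-place step links it to compound 1. Compound 3 `Cc1cc(-c2nc3ccccc3s2)ccc1N` has methyl in place of iodo on an aromatic carbon, ortho to an amino group and meta to a group of 9 heavy atoms (methyl in place of iodo on an aromatic carbon). For the measured compounds named here, no measured step covers this change, so the expectation in this assay is for a small shift toward weaker values, possibly none beyond the scatter. The expected step is a number no lower from compound 1 to compound 3 (the limit leaves the size open). The reading may again be only a limit. Compound 3 is estimated at 1 nM, with an expected range of 0.2 nM to 20 nM.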

Compound 3, half-maximal inhibitory concentration: < 1 nM
Compound 3 was reported as a limit (the forecaster's own chance of this, stated with the estimate: 60%); the middle value lies on the limit itself.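

Compound 1 and compound 3 both read as limits in this assay, so no step from one to the other can be read: the limit of < 1 nM in this assay, at which 2 of the 3 values shown sit.

Going by these compounds, the true values of compound 1 and compound 3 stay open, and with them whether methyl in place of iodo changes the reading at all.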